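The source may hold more compounds than are shown below. What is called first, only, known or untested is meant among the compounds shown, and "the series" means these compounds.

Series notes. Compound 3 `COc1cc(/C=N/Nc2nc3ccccc3s2)ccc1O` and compound 1 `Oc1ccc(/C=N/Nc2nc3ccccc3s2)cc1O` share one core; compound 2 `COc1cc(/C=N/NC(=O)OCc2ccccc2)ccc1O` carries a different core, and the difference between the two cores is not broken down here. In a functional assay on cells (Mus musculus) for cytotoxicity, read by MTT assay, with a stated time of 24 h, tested at 1 uM (on this read-out lower numbers stand for a weaker effect and higher numbers for a stronger effect at the one concentration tested), compound 3 gives 44%, compound 1 gives 33% and compound 2 gives 73%, the highest of the three numbers.

Within the first core the change hydrogen in place of methyl on an oxygen on an aromatic ring is measured: it gave a number 11 percentage points lower from compound 3 to compound 1 (beyond the scatter), a modest step downward that lies beyond the scatter.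

Compound 4 `O=C(N/N=C/c1ccc(O)c(O)c1)OCc1ccccc1` has not been measured. It stands to compound 2 as compound 1 stands to compound 3: the change hydrogen in place of methyl on an oxygen on an aromatic ring is the same change, at the same place, with aromatic carbon as the other neighbour on the oxygen in both cases. Going by the values given here, the expected step of a number 11 percentage points lower from compound 2 to compound 4 (beyond the scatter) rests on the single measured example of this change, since compound 1 against compound 3 showed a number 11 percentage points lower from compound 3 to compound 1 (beyond the scatter); with only one example and a different core, the expectation is loose. In this assay compound 4 is therefore expected to give about 62%, estimated to fall between 48% and 76%.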

Compound 4, a percentage reported as activity, at one concentration (the size of the read-out at that concentration, not a potency): 48%
Estimate against measurement, compound 4: 14 percentage points above; measured number inside the range.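

In this assay the change from methoxy to hydroxy gave a number 25 percentage points lower from compound 2 to compound 4 (beyond the scatter), so the downward direction seen on the core of compound 1 recurs on the core of compound 2. The two steps cannot be told apart in size, and on these two cores the change carries over as far as repeated measurements of this kind can resolve: the same change on two cores in this assay, a number 11 percentage points lower (beyond the scatter) from compound 3 to compound 1 and a number 25 percentage points lower (beyond the scatter) from compound 2 to compound 4, 14 percentage points apart, within the scatter of two such steps. This rests on just two pairs, at one place and at a single concentration, and it shows neither that the step has a fixed size nor that it would hold on any other core.

The compounds shown carry only methyl or hydrogen on this oxygen, so the effect of an ethyl group or a longer chain there, or of an amine in place of the hydroxy, remains open. As far as these compounds go, how the step behaves across a range of concentrations also remains open.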